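The source may report more compounds than this note shows. Statements on the series, on what has been measured and on what is new or still open speak of the compounds shown alone.

Measured compounds:
- compound 1 `COC(=O)CCCCCOc1cc(-c2ccccc2)cc(-c2ccccc2)n1`: 1000 nM
- compound 2 `O=C(O)CCCCCOc1cc(-c2ccccc2Cl)cc(-c2ccccc2)n1`: > 10000 nM
- compound 3 `CC(CCCCOc1cc(-c2ccccc2)cc(-c2ccccc2F)n1)C(=O)O`: 70 nM

In a functional assay on cells for inhibition of leukotriene B4 receptor 1 (Homo sapiens) (on this read-out higher numbers stand for weaker inhibition and lower numbers for stronger inhibition), compound 1 gives 1000 nM, the higher of the two numbers available. Compound 3 gives 70 nM, a lower number that lies beyond the scatter. Compound 2 reaches only the assay limit of > 10000 nM in this assay, at which 1 of the 3 values shown sits, and gives no number.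

Compound 4 `O=C(O)CCCCOc1cc(-c2ccccc2)cc(-c2ccccc2)n1` differs from compound 1 by carboxy in place of (methoxycarbonyl)methyl on a saturated chain carbon, four bonds along the chain from an oxygen on an aromatic ring. Among the compounds with values here, no step between measured compounds covers this change; both compounds carrying a free carboxy group, compound 3 and compound 2, sit on either side of compound 1. Compound 4 is expected to inhibit somewhat more strongly than compound 1, with a step of a 3.3-fold lower number from compound 1 to compound 4 (0.52 log units; beyond the scatter) somewhat beyond the scatter, given that compound 3 gives 70 nM. The estimate for compound 4 is 300 nM, within a range of 60 nM to 1500 nM.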

Compound 4, half-maximal inhibitory concentration: 20000 nM
The estimate for compound 4 lay 67-fold (1.82 log units) below the measured number; the measured number lies above the stated range.
By their numbers in this assay, from the lowest: compound 3; then compound 1; then compound 4.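

The change from (methoxycarbonyl)methyl to carboxy at this position, four bonds along the chain from an oxygen on an aromatic ring, weakens inhibition, with a 20-fold higher number from compound 1 to compound 4 (1.30 log units; beyond the scatter). Within the data shown here, on this otherwise unchanged core, then, the free carboxy compound is the weaker of the pair, a direct comparison that the earlier compounds did not offer. Nothing measured here accounts for the size of this step.

The change shortens the chain and frees the acid together, so their shares remain unseparated. A methyl ester on the chain of compound 4, a carboxylic acid on the chain of compound 1, or a terminal primary amide would separate them.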